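Furan-2-yl to ethynyl in the series

A few compounds are considered here, and "the series" means these few. Any claim that something is new, unique, unknown or untested is made for them only; others in the source may bear on it.

Measured so far in a functional assay on HCT-116 cells (Homo sapiens), read by MTT assay, with a stated time of 72 h; a higher number here means a weaker inhibitor, a lower number a stronger inhibitor
- compound 1 `COc1ncnc2c1c(-c1ccccc1)cn2[C@@H]1O[C@H](CO)[C@@H](O)[C@H]1O` gives > 20000 nM (a limit)
- compound 2 `CSc1ncnc2c1c(-c1ccccc1)cn2[C@@H]1O[C@H](CO)[C@@H](O)[C@H]1O` gives > 20000 nM (a limit)
- compound 3 `CNc1ncnc2c1c(-c1ccco1)cn2[C@@H]1O[C@H](CO)[C@@H](O)[C@H]1O` gives 440 nM

In this assay, within the data shown here, compound 3 holds the only number, while compound 1 and compound 2 stand only at a limit, as the limit of > 20000 nM in this assay, at which 2 of the 3 values shown sit, records. Moving on to compound 4 `C#Cc1cn([C@@H]2O[C@H](CO)[C@@H](O)[C@H]2O)c2ncnc(NC)c12`, ethynyl takes the place of furan-2-yl on an aromatic carbon (ethynyl in place of furan-2-yl on an aromatic carbon). Among the measured compounds shown here, the one measured step is a step that the two limits leave unreadable from compound 1 to compound 2 and concerns a different exchange, so it supplies no size to carry over. For the measured compounds named here, no measured step tests the present exchange, and no step beyond the scatter is therefore expected, with wide uncertainty in either direction. The expectation rests on compound 3 (440 nM) as the sole anchor. The estimated change is a 1.1-fold lower number from compound 3 to compound 4 (0.04 log units; within the scatter) in this assay as the working figure. For compound 4 the estimated value is 400 nM, with an expected range from 60 nM to 3000 nM (both ends estimated).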

Compound 4, half-maximal inhibitory concentration: > 20000 nM
Compound 4: only a limit was reported; the forecaster's own chance of this, stated with the estimate: 8%; middle value at least 50-fold (1.69 log units) away from the limit.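

In this assay, among these compounds, the exchange of furan-2-yl for ethynyl on this aromatic carbon gives an at least 45-fold higher number from compound 3 to compound 4 (1.65 log units; beyond the scatter) and is the first readable step, showing that the number at this position depends strongly on the group held there. On these data alone, compound 4 gives > 20000 nM as a limit and not a number, so the full size of the step stays open. Among the compounds shown here, compound 3 remains the only compound with a measured number, and the limit now marks most of the set: the limit of > 20000 nM in this assay, at which 3 of the 4 values shown sit.

Compound 1 and compound 2 differ from compound 3 in more than one place, so they do not show which feature of furan-2-yl matters. Open, as far as these compounds go, is how thiophen-2-yl, a plain ethyl group or a longer alkyne chain would read at this carbon on the core of compound 3.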